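A few compounds are considered here, and "the series" means these few. Any claim that something is new, unique, unknown or untested is made for them only; others in the source may bear on it.

Measured compounds:
Compound 1 `c1ccc(CN(CCCCN(C[C@H]2Cc3ccccc3CN2)[C@H]2CCCc3cccnc32)Cc2ccccc2)cc1`: > 16700 nM
Compound 2 `c1ccc2c(c1)CN[C@@H](CN(CCCCNCC1CCOCC1)[C@H]1CCCc3cccnc31)C2`: 52.9 nM
Compound 3 `FC1(F)CCC(NCc2ccc(CN(C[C@H]3Cc4ccccc4CN3)[C@H]3CCCc4cccnc43)cc2)CC1`: 143 nM

In a functional assay on cells for antagonist activity at C-X-C chemokine receptor type 4 (Homo sapiens), read by fluorescence and calcium flux, with stated times of 25 min and 90 s (on this read-out higher numbers stand for weaker inhibition and lower numbers for stronger inhibition), compound 2 gives 52.9 nM, the lower of the two numbers available. Compound 3 gives 143 nM, a number that sits beyond the usual scatter above compound 2. For compound 1 the result is only a limit, (the limit of > 16700 nM in this assay, at which 1 of the 3 values shown sits), and not a number.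

Compound 4 `C(=C/CN(C[C@H]1Cc2ccccc2CN1)[C@H]1CCCc2cccnc21)\CNCc1ccccn1` is obtained from compound 2 by a single change: a group of 11 heavy atoms (9 carbon, 2 nitrogen; one six-membered aromatic ring with 1 hetero atom) in place of a group of 11 heavy atoms (9 carbon, 1 nitrogen, 1 oxygen; one six-membered non-aromatic ring with 1 hetero atom), on a saturated chain carbon bound to an amine nitrogen. For the measured compounds named here, no measured pair shows a change of this kind, so the expected step from compound 2 to compound 4 rests on the two numbers alone. Compound 4 is expected to stay close to compound 2, with a step of a 1.5-fold higher number from compound 2 to compound 4 (0.18 log units; within the scatter) in this assay, estimated at 80 nM with a range from 25 nM to 300 nM.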

Compound 4, half-maximal inhibitory concentration: 58.3 nM
The estimate for compound 4 lay 1.4-fold (0.14 log units) above the measured number; low and high end bracket the measured number.
By their numbers in this assay, from the lowest: compounds 2 and 4 (each within the scatter of the next); then compound 3. At a limit, above all of these: compound 1.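

In this assay, for the compounds shown here, the first pair that differs in one place gives a 1.1-fold higher number from compound 2 to compound 4 (0.04 log units; within the scatter), so on a saturated chain carbon bound to an amine nitrogen, the group with a six-membered aromatic ring with 1 hetero atom and the group with a six-membered non-aromatic ring with 1 hetero atom cannot be told apart. Nothing measured here gives a cause for this result. The entering group also carries a double bond outside aromatic rings, so the compounds shown leave open what the ring and the double bond each contribute. Going by these compounds, whether a carboxylic acid or a longer chain would fit this place also stays open.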